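The compounds below may be only part of what the source reports. "The series", "measured", "known", "first", "only" and "open" are said of these compounds alone.

Working notes on the series. Two compounds have been run in an ADME assay on Huh7.5.1 cells (Homo sapiens) for cytotoxicity, read by ATP content, with a stated time of 48 h (a lower number here means that less compound is tolerated, a higher number that more compound is tolerated), so far. Compound 1 `Cc1ccccc1-c1nc(CN2CCC(C(=O)NCCCN3CC(C)(C)CC(C)(C)C3)CC2)c(C)o1` gives 4380 nM in this assay. Compound 2 `Cc1oc(-c2c(Br)cccc2Br)nc1CN1CCC(C(=O)NCCCN2C[C@H](C)C[C@H](C)C2)CC1` gives 6500 nM in this assay. Within the data shown here, the gap between the two numbers is within the usual scatter of repeated measurements, so compound 2 and compound 1 cannot be told apart on cytotoxicity, and no single-point step between measured compounds is available from which to read how the aryl group on the core affects the read-out.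

Compound 3 `COc1cccc(F)c1-c1nc(CN2CCC(C(=O)NCCCN3C[C@H](C)C[C@H](C)C3)CC2)c(C)o1` is the next compound for this assay. It differs from compound 2 at one place: 2-fluoro-6-methoxyphenyl in place of 2,6-dibromophenyl on an aromatic carbon. Among the measured compounds shown here, with no measured step to rest on, the expectation is set by compound 2 alone, which gives 6500 nM in this assay. The change is expected to leave the half-maximal cytotoxic concentration about where compound 2 sits, with no step beyond the scatter in either direction; the estimated step is a 1.1-fold lower number from compound 2 to compound 3 (0.03 log units; within the scatter). For compound 3 the expected value in this assay is 6000 nM, with a range from 2500 nM to 14000 nM.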

Compound 3, half-maximal cytotoxic concentration: 37000 nM
The estimate for compound 3 lay 6.2-fold (0.79 log units) below the measured number; measured number outside the range, above it.
By their numbers in this assay, from the lowest: compounds 1 and 2 (each within the scatter of the next); then compound 3.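

In this assay, among these compounds, this is the first single change whose step can be read, and it shows that the aryl group on the aromatic carbon of the shared core can move the read-out beyond the scatter: 2-fluoro-6-methoxyphenyl in place of 2,6-dibromophenyl gives a 5.7-fold higher number from compound 2 to compound 3 (0.76 log units; beyond the scatter), so more compound is tolerated with the new group. The exchange removes both bromine atoms, brings in fluorine and oxygen, and takes the group from 0 hydrogen-bond acceptors to 1, while the six-membered aromatic carbon ring stays in place. This single pair cannot assign the step to any one of those differences, and no supporting measurement is available to explain it.

The compounds shown leave open whether the fluorine or the methoxy group alone would give a step of this size, or whether simply losing the bromine atoms would be enough; an unsubstituted phenyl, a phenyl carrying only a methoxy group or a phenyl carrying chlorine would separate these cases. They also leave open whether the step would hold with a pyridine ring at this position or with a different amine at the far end of the chain.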